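The compounds below may be only part of what the source reports. "The series", "measured", "known", "first", "only" and "open" are said of these compounds alone.

Compounds measured so far in a functional assay on PC-12 cells (Rattus norvegicus) for cytotoxicity, read by MTT assay, with stated times of 2 h and 24 h, tested at 5 uM; a lower number here means a weaker effect, a higher number a stronger effect of the compound at the concentration tested:
compound 1, `Cc1ccc(-n2nc(-c3ccc(C(F)(F)F)cc3O)nc2-c2ccccc2O)cc1`: 94.1%
compound 2, `Oc1cc(C(F)(F)F)ccc1-c1nc(-c2ccccc2O)n(-c2ccc(Br)cc2)n1`: 89.8%
compound 3, `Oc1cc(C(F)(F)F)ccc1-c1nc(-c2ccccc2O)n(-c2ccc(OC(F)(F)F)cc2)n1`: 84.9%

Compound 3 has the lowest of the three numbers, but the two steps that lead to it, a number 4.9 percentage points lower from compound 2 to compound 3 (within the scatter) and a number 9.2 percentage points lower from compound 1 to compound 3 (within the scatter), are both within the scatter, so neither separates it from the others. The three compounds share one core and differ only in the group carried on the aromatic nitrogen of that core. Compound 4, `COc1cccc(-n2nc(-c3ccc(C(F)(F)F)cc3O)nc2-c2ccccc2O)c1`, is the next member and has not yet been measured. It differs from compound 3 in one place: 3-methoxyphenyl in place of 4-(trifluoromethoxy)phenyl on an aromatic nitrogen.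

All three measured steps bear on this change, since each swaps the group on the same aromatic nitrogen: a number 4.3 percentage points lower from compound 1 to compound 2 (within the scatter), a number 9.2 percentage points lower from compound 1 to compound 3 (within the scatter) and a number 4.9 percentage points lower from compound 2 to compound 3 (within the scatter). None of them moves the read-out in this assay beyond the scatter. Among the compounds with values here, a swap to 3-methoxyphenyl has no measured counterpart, so the expectation rests on that pattern alone. The step of a number 2.1 percentage points higher from compound 3 to compound 4 (within the scatter) is therefore expected to stay within the scatter. The estimate for compound 4 in this assay is 87%, between 76% and 96%.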

Compound 4, a percentage reported as activity, at one concentration (the size of the read-out at that concentration, not a potency): 96.8%
The estimate for compound 4 lay 9.8 percentage points below the measured number; the whole stated range lies below it.
By their numbers in this assay, from the lowest: compounds 3, 2, 1 and 4 (each within the scatter of the next, the first and the last beyond it).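

In this assay, within the data shown here, the swap to 3-methoxyphenyl from 4-(trifluoromethoxy)phenyl gives a number 11.9 percentage points higher from compound 3 to compound 4 (beyond the scatter) and is the only step so far on this aromatic nitrogen that passes the scatter, which shows that the group held here can move the read-out, if only modestly. The same entering group does not separate compound 4 from the other two compounds, with a number 7 percentage points higher from compound 2 to compound 4 (within the scatter) and a number 2.7 percentage points higher from compound 1 to compound 4 (within the scatter), so the change registers against compound 3 alone and not as a general shift for 3-methoxyphenyl. Nothing measured here accounts for the step from compound 3 to compound 4.

The swap changes both the group on the phenyl ring and where that group sits, and the compounds shown cannot tell these two apart, so it remains open which of them goes with the higher number. All four compounds also carry a substituted phenyl ring on this nitrogen, which leaves open how the read-out would respond to a phenyl ring bearing an amine or a carboxylic acid, or to a longer alkyl chain in place of the ring.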